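The compounds below may be only part of what the source reports. "The series", "measured", "known", "first", "only" and "open" are said of these compounds alone.

Compound 2 `Cc1cccc(-n2nc(-c3ccccc3)nc2CNc2ccc(C(=O)NO)cc2)c1` and compound 1 `O=C(NO)c1ccc(NCc2nc(-c3ccc(Br)o3)nn2-c2ccccc2)cc1` were both tested in an assay on Sf9 cells for inhibition of protein deacetylase HDAC6 (Homo sapiens), read by fluorescence, with a stated time of 40 min, tested at 100 nM; a lower number here means less inhibition, a higher number more inhibition at the concentration tested (going by the name of the read-out). Compound 2 gives 66%, the higher of the two numbers recorded, while compound 1 gives 55.8%, a gap that lies beyond the usual scatter of this assay. Compound 3 `O=C(NO)c1ccc(NCc2nc(-c3ccccc3)nn2-c2ccccc2Cl)cc1` has not yet been measured in this assay. It differs from compound 2 in one place: 2-chlorophenyl in place of 3-methylphenyl on an aromatic nitrogen. Among the measured compounds shown here, with no measured pair available that isolates this change, the size of the step is uncertain, and the two values on hand give no basis for expecting a large move in either direction. Compound 3 is therefore expected to sit close to compound 2, with a step from compound 2 to compound 3 of about a number 6 percentage points lower from compound 2 to compound 3 (within the scatter), small and within the scatter. Compound 3 is estimated to give 60%, with a plausible range from 45% to 75%.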

Compound 3, a percentage reported as inhibition, at one concentration (the size of the read-out at that concentration, not a potency): 64.6%
Compound 3: middle estimate off by 4.6 percentage points, on the low side; measured number inside the range.
By their numbers in this assay, from the lowest: compounds 1, 3 and 2 (each within the scatter of the next, the first and the last beyond it).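

In this assay, among the compounds shown here, putting 2-chlorophenyl in place of 3-methylphenyl on the aromatic nitrogen gives a number 1.4 percentage points lower from compound 2 to compound 3 (within the scatter), the first reading of a change at this position with the rest of the molecule held constant. At this single concentration, the two aryl groups cannot be told apart, although both the substituent and its place on the phenyl ring differ. Nothing available offers an explanation for this result.

For the compounds shown here, since both features change together in this one pair, the contribution of each remains unresolved, and a single concentration gives no potency for either compound. On these data alone, it also remains open whether this position would accommodate a group of a different kind, such as a carboxylic acid, an amine or a longer alkyl chain, in place of these aryl groups.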